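The source may hold more compounds than are shown below. What is called first, only, known or untested is meant among the compounds shown, and "the series" means these compounds.

Compound 1 `N/C(=N\NC(=S)N1CCCCCC1)c1ccccn1` and compound 2 `Cc1ccnc(/C(N)=N/NC(=S)N2CCN(c3ccccn3)CC2)c1` have both been tested in a functional assay on HeLa cells (Homo sapiens) for cytotoxicity, read by MTT assay, with a stated time of 72 h, tested at 1 uM; on this read-out lower numbers stand for less inhibition of growth and higher numbers for more inhibition of growth at the one concentration tested. In this assay compound 1 gives 21.3%. In this assay compound 2 gives 40.4%, a value beyond the usual scatter above compound 1, which therefore stands as the lower of the two. Compound 2 differs from compound 1 in more than one place, so its higher number cannot be tied to any single change. Compound 3 `Cc1ccnc(/C(N)=N/NC(=S)N2CCCCCC2)c1`, not yet measured, carries one alteration relative to compound 1: methyl in place of hydrogen on an aromatic carbon, a methyl in place of hydrogen on an aromatic carbon, opposite the ring nitrogen. Within the data shown here, no measured pair isolates this change, so the step of a number 4.7 percentage points higher from compound 1 to compound 3 (within the scatter) is expected to be small, within or near the scatter. Compound 3 is estimated to give 26%, with a likely range from 10% to 42%.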

Compound 3, percent growth inhibition at one concentration: 43.2%
Estimate against measurement, compound 3: 17.2 percentage points below; measured number outside the range, above it.
By their numbers in this assay, from the lowest: compound 1; then compounds 2 and 3 (each within the scatter of the next).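

In this assay a methyl in place of hydrogen on an aromatic carbon, opposite the ring nitrogen, gives a number 21.9 percentage points higher from compound 1 to compound 3 (beyond the scatter) and so shows that this one added carbon can change the read-out on its own. The earlier pair differed in more than one place and could not show this. Nothing available accounts for the rise in growth inhibition. As far as these compounds go, whether an ethyl group, a methoxy group or an amine at this place would give a similar number remains open. So does the effect of a methyl on another carbon of this ring.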